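Quinoline ureas: cytotoxicity in human kidney cells, first two points

The compounds below may be only part of what the source reports. "The series", "measured", "known", "first", "only" and "open" are said of these compounds alone.

Measured compounds:
compound 1, `Cc1cc(NC(=O)Nc2ncccc2C)c2ccccc2n1` — > 25000 nM
compound 2, `Cc1cc(NC(=O)Nc2ccc(Cl)c(Cl)c2)c2ccccc2n1` — > 25000 nM

Both points come from an ADME assay on HEK293 cells (Homo sapiens) for cytotoxicity, with a stated time of 72 h; a higher number here means that more compound is needed for the effect, a lower number that less compound is needed. Compound 1 gives > 25000 nM in this assay, which is a limit of the assay and not a number. Compound 2 gives > 25000 nM, again a limit. Among the measured compounds shown here, compound 1 therefore stands at the limit of > 25000 nM in this assay, at which 2 of the 2 values shown sit; no finished number exists for any compound in this assay, and no step between measured compounds can be counted.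

The next compound is compound 3, `Cc1cc(NC(=O)Nc2cccc(F)c2)c2ccccc2n1`. Against compound 1 the change is 3-fluorophenyl in place of 3-methylpyridin-2-yl on an amide-type nitrogen. With both known values sitting at the limit, no step beyond the scatter is expected from this change in this assay. Compound 3 is expected at 30000 nM, in a range from 12000 nM to 80000 nM. The expected step that the limit leaves unreadable from compound 1 to compound 3 is estimated as none beyond the scatter, with the assay most likely again returning only a limit.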

Compound 3, half-maximal effective concentration: > 25000 nM
Compound 3 gave a limit, no number (the forecaster's own chance of this, stated with the estimate: 80%); the middle value is on the limit's open side.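

Among the compounds shown here, compound 1 and compound 3 both return only a limit in this assay, so no step between them can be read: the limit of > 25000 nM in this assay, at which 3 of the 3 values shown sit.

The compounds shown leave open whether any group on the amide-type nitrogen gives a finished number in this assay.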